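Triazole-linked sulfonamide series: removal of the aryloxy group

A few compounds are considered here, and "the series" means these few. Any claim that something is new, unique, unknown or untested is made for them only; others in the source may bear on it.

compound 1 `COc1cc2c(cc1OC)CN(S(=O)(=O)c1ccc(-n3cc(COc4ccc(C=O)cc4)nn3)cc1)CC2`: 12500 nM
compound 2 `COc1cc2c(cc1OC)CN(S(=O)(=O)c1ccc(-n3cc(COc4ccccc4C)nn3)cc1)CC2`: 1480 nM
compound 3 `COc1cc2c(cc1OC)CN(S(=O)(=O)c1ccc(-n3cc(COc4cc(C=O)ccc4OC)nn3)cc1)CC2`: 41400 nM

In a functional assay on HepG2 cells (Homo sapiens) for cytotoxicity, read by MTT assay, with a stated time of 48 h (a lower number here means a stronger inhibitor, a higher number a weaker inhibitor), compound 3 gives the highest number of the three, with compound 1 nearest (a 3.3-fold higher number from compound 1 to compound 3 (0.52 log units; beyond the scatter)) and compound 2 furthest (a 28-fold higher number from compound 2 to compound 3 (1.45 log units; beyond the scatter)). Compound 4 `COc1cc2c(cc1OC)CN(S(=O)(=O)c1ccc(-n3cc(CO)nn3)cc1)CC2` differs from compound 3 by hydrogen in place of 5-formyl-2-methoxyphenyl on an oxygen on a saturated carbon. For the measured compounds named here, none of the measured steps removes the aryl group altogether; the nearest comparisons are an 8.4-fold lower number from compound 1 to compound 2 (0.93 log units; beyond the scatter) and a 28-fold higher number from compound 2 to compound 3 (1.45 log units; beyond the scatter), which show that changes on this aryl move the number substantially in either direction. Going by the values given here, with no direct precedent, the expected step of a 4.1-fold lower number from compound 3 to compound 4 (0.62 log units; beyond the scatter) is a move back toward the middle of the measured range, with wide uncertainty. Compound 4 is expected to give 10000 nM in this assay, within a range of 2000 nM to 50000 nM.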

Compound 4, half-maximal inhibitory concentration: 31800 nM
Estimate against measurement, compound 4: 3.2-fold (0.50 log units) below, within the range that was stated.
By their numbers in this assay, from the lowest: compound 2; then compound 1; then compounds 4 and 3 (each within the scatter of the next).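

In this assay the change to hydroxymethyl gives a 1.3-fold lower number from compound 3 to compound 4 (0.11 log units; within the scatter) and thus does not separate 5-formyl-2-methoxyphenyl from hydrogen on this oxygen. By contrast, a 2.5-fold higher number from compound 1 to compound 4 (0.41 log units; beyond the scatter) and a 21-fold higher number from compound 2 to compound 4 (1.33 log units; beyond the scatter) show that 4-formylphenyl and 2-methylphenyl do separate from hydrogen, so the presence of an aryl group here does not alone set the number. No available measurement explains these differences.

From the compounds shown here alone, whether plain phenyl on this oxygen would keep the number of compound 2 remains open. So does the outcome with an amine or a carboxylic acid in place of hydroxy.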